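Removing the Nitrile from Compound 3

The source may report more compounds than this note shows. Statements on the series, on what has been measured and on what is new or still open speak of the compounds shown alone.

Of the compounds shown here, three have so far been measured in an assay on isolated protein for inhibition of Aromatase (Homo sapiens), read by fluorescence and colorimetric assay, with a stated time of 30 min; on this read-out higher numbers stand for weaker inhibition and lower numbers for stronger inhibition. Compound 1 `N#Cc1ccc(C(c2ccc(C#N)cc2)n2cc(C3CCCCC3)nn2)cc1` gives 19300 nM, compound 2 `N#Cc1ccc(Cn2ccnn2)cc1` gives 100 nM, and compound 3 `N#Cc1ccc(Cn2cc(C3CCCCC3)nn2)cc1` gives 10700 nM. Compound 3 therefore stands second highest of the three numbers in this assay. The step of a 1.8-fold lower number from compound 1 to compound 3 (0.26 log units; within the scatter) leaves those two compounds within the scatter of each other, whereas the step of a 110-fold higher number from compound 2 to compound 3 (2.03 log units; beyond the scatter) is large and clearly beyond it.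

Compound 4 `c1ccc(Cn2cc(C3CCCCC3)nn2)cc1` differs from compound 3 in one place: hydrogen in place of cyano on an aromatic carbon. Neither measured step bears directly on this change. The step of a 1.8-fold lower number from compound 1 to compound 3 (0.26 log units; within the scatter) concerned a 4-cyanophenyl on a saturated chain carbon, and the step of a 110-fold higher number from compound 2 to compound 3 (2.03 log units; beyond the scatter) concerned a cyclohexyl on an aromatic carbon; the cyano group itself was present in all three measured compounds and has never been varied. Going by the values given here, the expectation for compound 4 in this assay is thus a weakening of moderate size, a 2.8-fold higher number from compound 3 to compound 4 (0.45 log units; beyond the scatter), with considerable uncertainty because the only precedent for a change on this part of the molecule is absent. Compound 4 is accordingly estimated at 30000 nM, within a range from 9000 nM to 100000 nM.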

Compound 4, half-maximal inhibitory concentration: 7980 nM
Compound 4: middle estimate off by 3.8-fold (0.58 log units), on the high side; the measured number lies below the stated range.
By their numbers in this assay, from the lowest: compound 2; then compounds 4, 3 and 1 (each within the scatter of the next, the first and the last beyond it).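

In this assay, replacing the nitrile with hydrogen on an aromatic carbon of a six-membered aromatic ring of carbon only, para to a large group, gives a 1.3-fold lower number from compound 3 to compound 4 (0.13 log units; within the scatter). Going by these compounds alone, the nitrile was present in all the earlier compounds, so this is the first reading of what it does at this position, and it shows that, with the cyclohexyl in place, the loss of its two heavy atoms and one hydrogen-bond acceptor produces no change beyond the scatter. No measurement is available that would explain this result.

What the compounds shown leave open is whether the same change would also stay within the scatter without the cyclohexyl, in the setting of compound 2 at 100 nM, since a result obtained on the weaker cyclohexyl compounds need not carry over to that one. As far as these compounds go, it is equally open how a carboxylic acid, an amine or a fluorine atom on the same aromatic carbon would compare with the nitrile and with hydrogen in this assay series.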